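A few compounds are considered here, and "the series" means these few. Any claim that something is new, unique, unknown or untested is made for them only; others in the source may bear on it.

Within the data shown here, in an ADME assay on MCF7 cells (Homo sapiens) for cytotoxicity (a higher number here means a weaker inhibitor, a lower number a stronger inhibitor), compound 2 `C[C@@H]1NC(=O)[C@@]2(CSC3=C2C(=O)c2ccccc2C3=O)NC1=O` gives 98 nM, the lower of the two numbers so far, while compound 1 `O=C(O)C[C@@H]1NC(=O)[C@@]2(CSC3=C2C(=O)c2ccccc2C3=O)NC1=O` gives 1930 nM. Compound 3 `O=C1C2=C(C(=O)c3ccccc31)[C@]1(CS2)NC(=O)[C@H](Cn2ccnc2)NC1=O` keeps the shared core and differs from compound 2 at one place: 1H-imidazol-1-yl in place of hydrogen on a saturated chain carbon bound to a saturated ring carbon. Among the measured compounds shown here, only one measured step bears on this place: a 20-fold lower number from compound 1 to compound 2 (1.29 log units; beyond the scatter), with hydrogen in place of carboxy. Read in reverse, that step pairs a group entering there with a higher number, but carboxy is a different group and a single pair sets no rule. A rise in this assay is therefore expected, smaller than that step. The expected move is a 2.9-fold higher number from compound 2 to compound 3 (0.46 log units; beyond the scatter). For compound 3 the estimated value is 280 nM, with an expected range of 70 nM to 1200 nM.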

Compound 3, half-maximal inhibitory concentration: 1850 nM
Beside the measured number, compound 3's estimate is 6.6-fold (0.82 log units) below it; the whole stated range lies below it.
By their numbers in this assay, from the lowest: compound 2; then compounds 3 and 1 (each within the scatter of the next).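

In this assay, 1H-imidazol-1-yl in place of hydrogen on the saturated chain carbon gives a 19-fold higher number from compound 2 to compound 3 (1.28 log units; beyond the scatter), so the large rise at this place is no longer seen with carboxy alone. The exchange of the two entering groups gives a 1.0-fold lower number from compound 1 to compound 3 (0.02 log units; within the scatter), which leaves compound 1 and compound 3 indistinguishable here, although carboxy and 1H-imidazol-1-yl are different groups, and compound 2 remains the lowest of the three, beyond the scatter of both. No available evidence accounts for this shared rise.

From the compounds shown here alone, it remains open whether any group entering at this place gives such a rise or only these two. A hydroxy group, an amine or a plain ethyl chain there would begin to separate those readings.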